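Swapping amino for methyl on a weakly cytotoxic compound

This account rests on a few compounds, and the source may have more. Where it says the series, first, only, none or still open, it means among the compounds named here.

Measured in a functional assay on A549 cells (Homo sapiens) for cytotoxicity, read by MTT assay, with a stated time of 68 h (a higher number here means a weaker inhibitor, a lower number a stronger inhibitor), are two compounds:
Compound 1 `Nc1cccc(-c2cccc(NC(=O)C(Cl)Cl)c2)c1` gives 50000 nM
Compound 2 `CC(C)c1ccc(-c2cc(NC(=O)C(Cl)Cl)cc(-c3ccc(C(C)C)cc3)c2)cc1` gives 17400 nM

Compound 1 has the higher number of the two and so is the weaker inhibitor, with compound 2 lower by more than the usual scatter. Among the compounds with values here, compound 3 `Cc1cccc(-c2cccc(NC(=O)C(Cl)Cl)c2)c1` keeps the core of compound 1, and methyl in place of amino on an aromatic carbon is its only change. Within the data shown here, no measured pair differs in just one place, so this expectation rests on little evidence. No step beyond the scatter is expected in this assay for this swap. The estimated step of a 1.4-fold lower number from compound 1 to compound 3 (0.15 log units; within the scatter) is small and points toward a lower number. For compound 3 the expected value is 35000 nM within an estimated range of 15000 nM to 80000 nM overall.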

Compound 3, half-maximal inhibitory concentration: 8700 nM
The estimate for compound 3 lay 4.0-fold (0.60 log units) above the measured number; measured number below the stated range.
By their numbers in this assay, from the lowest: compounds 3 and 2 (each within the scatter of the next); then compound 1.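

At this place on the ring, the group clearly matters in this assay: methyl in place of amino gives a 5.7-fold lower number from compound 1 to compound 3 (0.76 log units; beyond the scatter) with the rest of the molecule unchanged. Within the data shown here, this is the first single-change comparison here, and it shows that one heavy atom can shift the number beyond the scatter. Nothing shown here explains the step. On these data alone, it remains open whether the lower number depends on methyl itself or simply on the loss of amino. An ethyl group, a methoxy group or a carboxylic acid at this place would help separate those two readings.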